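A few compounds are considered here, and "the series" means these few. Any claim that something is new, unique, unknown or untested is made for them only; others in the source may bear on it.

For the measured compounds named here, in an ADME assay on NHDF cells (Homo sapiens) for cytotoxicity, read by MTT assay, with a stated time of 72 h (a lower number here means a stronger inhibitor, a higher number a weaker inhibitor), compound 1 (`COc1ccc(/C=C2\CCC/C(=C\c3ccc(OC)c(OC)c3)C2=O)cc1OC`) gives 9700 nM and compound 2 (`COc1cc(/C=C2\CCC/C(=C\c3ccc(OC)c(OC)c3)C2=O)cc(OC)c1`) gives 6500 nM as the only numbers so far. Compound 2 thus stands level with compound 1, the two values lying within the usual scatter of each other. Compound 3 (`COc1ccc(/C=C2\CCC/C(=C\c3cc(OC)c(OC)c(OC)c3)C2=O)cc1OC`) differs from compound 2 by one change (methoxy in place of hydrogen on an aromatic carbon), methoxy in place of hydrogen on an aromatic carbon, ortho to two methoxy groups and para to a large group. Going by the values given here, no measured pair differs in one place alone, so no step shows directly what such a change does. With compound 1 at 9700 nM and compound 2 at 6500 nM so close together, no step beyond the scatter is expected in this assay and neither direction is favoured. The estimated change is small (a 1.1-fold higher number from compound 2 to compound 3 (0.03 log units; within the scatter)) on this evidence. For compound 3 the expected value is 7000 nM within an estimated range of 3000 nM to 15000 nM as a working figure.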

Compound 3, half-maximal inhibitory concentration: 5800 nM
For compound 3 the middle estimate is 1.2-fold (0.08 log units) above the measured one; the measured number falls inside the stated range.
By their numbers in this assay, from the lowest: compounds 3, 2 and 1 (each within the scatter of the next).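

Placing a methoxy group on the aromatic carbon ortho to two methoxy groups and para to a large group gives a 1.1-fold lower number from compound 2 to compound 3 (0.05 log units; within the scatter) in this assay, and the same kind of change also gives a 1.7-fold lower number from compound 1 to compound 3 (0.22 log units; within the scatter), so both of these first readable steps lie within the scatter. Three methoxy groups on this ring therefore leave the number in this assay level with that of either ring pattern carrying two, and this position accepts a methoxy group without a step beyond the scatter. Nothing available accounts for this result.

The compounds shown leave open whether an amine, a carboxylic acid or a longer chain such as ethoxy at this position would give a step beyond the scatter. They also leave open whether removing methoxy groups from these rings would move the number in this assay at all.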